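Pyrrolidine nitrogen substituent: carbamate, amide, benzyl

The compounds below may be only part of what the source reports. "The series", "measured", "known", "first", "only" and "open" are said of these compounds alone.

Among the three measured compounds, compound 3 `CC(C)(C)C(=O)N1CCC[C@H]1C(=O)N1CCC(NS(=O)(=O)c2cc(S(=O)(=O)c3ccccc3)ccc2C(F)(F)F)CC1` carries the highest number in a functional assay on U2OS cells for antagonist activity at proto-oncogene Wnt-3 (Homo sapiens), read by a luciferase reporter, with a stated time of 18 h; a lower number here means that less compound is needed, a higher number that more compound is needed for the effect: compound 3 gives 270 nM. Compound 1 `CC(C)(C)OC(=O)N1CCC[C@H]1C(=O)N1CCC(NS(=O)(=O)c2cc(S(=O)(=O)c3ccccc3)ccc2C(F)(F)F)CC1` gives 60 nM and compound 2 `CC(C)(C)OC(=O)N1CCC[C@@H]1C(=O)N1CCC(NS(=O)(=O)c2cc(S(=O)(=O)c3ccccc3)ccc2C(F)(F)F)CC1` gives 210 nM. The step of a 3.5-fold higher number from compound 1 to compound 2 (0.54 log units; beyond the scatter) rests on (the fact that compounds 1 and 2 differ only in the configuration as drawn); the step of a 4.5-fold higher number from compound 1 to compound 3 (0.65 log units; beyond the scatter) shows that tert-butyl for tert-butoxy on the carbonyl carbon raises the number, while the step of a 1.3-fold higher number from compound 2 to compound 3 (0.11 log units; within the scatter) is small. Compound 4 `O=C([C@@H]1CCCN1Cc1ccccc1)N1CCC(NS(=O)(=O)c2cc(S(=O)(=O)c3ccccc3)ccc2C(F)(F)F)CC1` differs from compound 3 by benzyl in place of (tert-butyl)carbonyl on an amine nitrogen in a ring. Within the data shown here, no measured step removes the carbonyl from this ring nitrogen, so only the two changes at this position guide the expectation, and both were modest. A modest further rise is expected, a 1.7-fold higher number from compound 3 to compound 4 (0.22 log units; within the scatter), so compound 4 is estimated at 450 nM, within 120 nM to 1800 nM.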

Compound 4, half-maximal effective concentration: 720 nM
The estimate for compound 4 lay 1.6-fold (0.20 log units) below the measured number; the range from low to high includes it.
By their numbers in this assay, from the lowest: compound 1; then compounds 2 and 3 (each within the scatter of the next); then compound 4.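

Replacing (tert-butyl)carbonyl with benzyl on the amine nitrogen in a ring removes the carbonyl from this position and gives a 2.7-fold higher number from compound 3 to compound 4 (0.43 log units; beyond the scatter) in this assay. Measured against the tert-butoxycarbonyl compounds, the same position gives a 3.4-fold higher number from compound 2 to compound 4 (0.54 log units; beyond the scatter) and a 12-fold higher number from compound 1 to compound 4 (1.08 log units; beyond the scatter), the latter the largest step in the set. Neither the amide nor the benzyl group at this nitrogen reaches the number of compound 1.

Nothing given here accounts for the rise with benzyl. On these data alone, whether an unsubstituted ring amine, a methyl group or a phenylsulfonyl group at this nitrogen would fall nearer compound 1 or compound 4 remains open.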